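Swapping a Bromophenyl for a Hydroxyphenyl: Cytotoxicity Outlook

The source may hold more compounds than are shown below. What is called first, only, known or untested is meant among the compounds shown, and "the series" means these compounds.

Compound 1 `CCc1ccc(-c2nc3c(c(C)nn3-c3ccccc3)c(-c3ccccc3Br)c2C#N)cc1` was tested in an ADME assay on BJ cells (Homo sapiens) for cytotoxicity, with a stated time of 72 h; on this read-out lower numbers stand for an effect already at smaller amounts and higher numbers for an effect only at larger amounts of compound. In this assay compound 1 gives only a limit, > 20000 nM. Compound 2 `CCc1ccc(-c2nc3c(c(C)nn3-c3ccccc3)c(-c3ccccc3Cl)c2C#N)cc1` carries chloro in place of bromo on an aromatic carbon. In this assay compound 2 likewise gives only a limit, > 20000 nM. The step that the two limits leave unreadable from compound 1 to compound 2 therefore cannot be read as a number. Compound 3 `CCc1ccc(-c2nc3c(c(C)nn3-c3ccccc3)c(-c3ccc(O)cc3)c2C#N)cc1` differs from compound 1 by 4-hydroxyphenyl in place of 2-bromophenyl on an aromatic carbon. Within the data shown here, no measured step covers such a change; the one step known, from bromo to chloro, is itself unreadable, and both values shown sit at the same limit (the limit of > 20000 nM in this assay, at which 2 of the 2 values shown sit). There is thus no basis for expecting a step beyond the scatter in either direction, and a further limit seems the most likely outcome. For compound 3 the estimate is 25000 nM, with a range from 8000 nM to 80000 nM, which means an expected step that the limit leaves unreadable from compound 1 to compound 3.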

Compound 3, half-maximal effective concentration: > 20000 nM
Compound 3 gave a limit, no number (the forecaster's own chance of this, stated with the estimate: 75%); the middle value is on the limit's open side.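

Compound 1, compound 2 and compound 3 all give only a limit, so no step between them can be read: the limit of > 20000 nM in this assay, at which 3 of the 3 values shown sit.

Going by these compounds, whether the 2-bromophenyl, 2-chlorophenyl and 4-hydroxyphenyl groups differ at all in this assay stays open.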